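Urotensin-2 receptor efficacy: trifluoromethyl in place of methoxy

The compounds below may be only part of what the source reports. "The series", "measured", "known", "first", "only" and "open" are said of these compounds alone.

Compound 1 `Cc1ccccc1NC(=O)NC(CCN(C)C)c1ccc(Cl)cc1` gives 175% in an assay on NIH3T3 cells with Urotensin-2 receptor (Homo sapiens) as the target; on this read-out higher numbers stand for larger maximal responses and lower numbers for smaller maximal responses.
Compound 2 `COc1ccc(NC(=O)NC(CCN(C)C)c2ccc(Cl)cc2)cc1` gives 195% in this assay.

Of the two numbers in this assay, compound 2 stands highest; the nearest is compound 1, and the move from it to compound 2 was a number 20 percentage points higher from compound 1 to compound 2 (beyond the scatter). That single step is the only one measured so far, and it concerns the substituted phenyl on the amide-type nitrogen, where 4-methoxyphenyl replaced 2-methylphenyl.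

Compound 3 `CN(C)CCC(NC(=O)Nc1ccc(C(F)(F)F)cc1)c1ccc(Cl)cc1` differs from compound 2 on that same phenyl: trifluoromethyl in place of methoxy on an aromatic carbon. Within the data shown here, the one measured step bears on this change only loosely, since it altered both the group and where it sits, whereas here only the group changes at the same place. With a modest effect from that step, the change to compound 3 is expected to move the number little, probably not beyond the scatter in either direction, and the estimated step is a number 10 percentage points lower from compound 2 to compound 3 (within the scatter). Compound 3 is therefore expected to give about 185% in this assay, within a range of 150% to 215%.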

Compound 3, largest response reached (reported as efficacy), in percent of the reference or control that the assay uses: 105%
Estimate against measurement, compound 3: 80 percentage points above; the measured number lies below the stated range.
By their numbers in this assay, from the lowest: compound 3; then compound 1; then compound 2.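

In this assay, among these compounds, the exchange of methoxy for trifluoromethyl on an aromatic carbon, para to a large group, gives a number 90 percentage points lower from compound 2 to compound 3 (beyond the scatter) and so counts as a large step, whereas the one earlier step, a number 20 percentage points higher from compound 1 to compound 2 (beyond the scatter) in size, was modest and changed both the group and its place on the phenyl. Here the place stays the same and only the group differs, so the pair shows that the maximal response in this series can depend strongly on the identity of this one substituent, with compound 3 at 105% against the far higher number of compound 2. Nothing measured here accounts for this large step.

The two compounds at this place leave open whether the fall is peculiar to trifluoromethyl or would also follow from a chlorine, a nitrile, a hydroxyl or a plain methyl on the same carbon. They also leave open how trifluoromethyl would behave on another carbon of that phenyl, and how an ethoxy group would compare with methoxy.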